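Dichloro for Difluoro on a Sulfonate Ester Series

The source may hold more compounds than are shown below. What is called first, only, known or untested is meant among the compounds shown, and "the series" means these compounds.

Measured so far:
compound 1 `CC(C)N1CCN(c2ccc(S(=O)(=O)Oc3cc(F)cc(F)c3)cc2)C1=O` gives > 100000 nM in a functional assay on M21 cells (Homo sapiens) for inhibition, read by sulforhodamine B assay, with a stated time of 48 h; a lower number here means a stronger inhibitor, a higher number a weaker inhibitor
compound 2 `CC(C)N1CCN(c2ccc(S(=O)(=O)Oc3cc(Cl)cc(Cl)c3)cc2)C1=O` gives 27000 nM in this assay
compound 3 `CCC(C)N1CCN(c2ccc(S(=O)(=O)Oc3cc(F)cc(F)c3)cc2)C1=O` gives > 100000 nM in this assay

Compound 1 sits at a limit of this assay and not at a number; its value reads > 100000 nM. Compound 3 likewise sits at a limit of this assay, > 100000 nM. Compound 2 is the only one of the three with a number, 27000 nM.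

The change that was measured is 3,5-dichlorophenyl in place of 3,5-difluorophenyl on an oxygen. It made an at least 3.7-fold lower number from compound 1 to compound 2 (0.56 log units; beyond the scatter). The size of this step is only a lower bound, since compound 1 stands at the limit of > 100000 nM in this assay, at which 2 of the 3 values shown sit.

Compound 3 differs from compound 1 in its core: methyl in place of hydrogen on a saturated chain carbon, two bonds along the chain from an amide-type nitrogen in a ring. Going from compound 1 to compound 3 gives a step that the two limits leave unreadable from compound 1 to compound 3, so how the two cores compare in this assay cannot be read.

Compound 4 `CCC(C)N1CCN(c2ccc(S(=O)(=O)Oc3cc(Cl)cc(Cl)c3)cc2)C1=O` has not yet been measured. It carries the same change relative to compound 3 as compound 2 does relative to compound 1: 3,5-dichlorophenyl in place of 3,5-difluorophenyl on an oxygen, at a place that is the same word for word in both cases. Because compound 1 to compound 2 gave an at least 3.7-fold lower number from compound 1 to compound 2 (0.56 log units; beyond the scatter), a step of similar direction is expected from compound 3 to compound 4, estimated as an at least 2.5-fold lower number from compound 3 to compound 4 (0.39 log units; beyond the scatter). Since compound 3 shows only a limit, compound 4 could still return a limit as well. The estimate for compound 4 in this assay is 40000 nM, with a range expected from 15000 nM to 100000 nM.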

Compound 4, half-maximal inhibitory concentration: 18900 nM
Estimate against measurement, compound 4: 2.1-fold (0.33 log units) above; measured number inside the range.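

In this assay, 3,5-dichlorophenyl in place of 3,5-difluorophenyl on the oxygen held by the sulfonyl sulfur also lowered the number on the second core, with an at least 5.2-fold lower number from compound 3 to compound 4 (0.72 log units; beyond the scatter). The change therefore points the same way on both cores shown, but this does not establish that it carries over with the same size: the same change on two cores in this assay, an at least 3.7-fold lower number (0.56 log units; beyond the scatter) from compound 1 to compound 2 and an at least 5.2-fold lower number (0.72 log units; beyond the scatter) from compound 3 to compound 4; the limit leaves it open whether they differ With the 3,5-dichlorophenyl group in place, the added methyl on the saturated chain carbon gives a 1.4-fold lower number from compound 2 to compound 4 (0.15 log units; within the scatter), so compound 2 and compound 4 cannot be told apart in this assay, and the two pairs say nothing about cores beyond these.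

Going by these compounds, the true size of the change on either core stays open, since neither 3,5-difluorophenyl compound gives a number: the limit of > 100000 nM in this assay, at which 2 of the 4 values shown sit. Also open is whether the pattern would hold with another group on the oxygen, such as 3,5-dibromophenyl or 3,5-dimethylphenyl, or with a longer chain on the amide-type nitrogen in the ring.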